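Replacing an Oxime Hydroxy with a Hydroxyethyl Chain

The compounds below may be only part of what the source reports. "The series", "measured", "known", "first", "only" and "open" are said of these compounds alone.

Compound 1 `Cc1ccc2[nH]c(=O)c(/C=N/O)cc2c1`: 389000 nM
Compound 2 `O=c1[nH]c2ccccc2cc1/C=N/O`: 463000 nM
Compound 3 `NS(=O)(=O)CC(=O)N/N=C/c1cc2ccccc2[nH]c1=O`: 256000 nM

All three measured compounds share one core and were tested in a functional assay, read by spectrophotometry, with a stated time of 5 min; a lower number here means a stronger inhibitor, a higher number a weaker inhibitor. Compound 1 gives the second highest of the three numbers. Within the data shown here, its nearest neighbour is compound 2, and the only measured step between compounds that differ in one place is a 1.2-fold higher number from compound 1 to compound 2 (0.08 log units; within the scatter), so removing the methyl from the ring changed nothing that can be told apart from noise. Among the measured compounds shown here, compound 3 gives 256000 nM, a lower number than compound 1, but the gap between the two is also within the scatter, and compound 3 differs from compound 1 in more than one place, so no single step can be drawn from it.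

Compound 4 `Cc1ccc2[nH]c(=O)c(/C=N/CCO)cc2c1` has not yet been measured. It differs from compound 1 in one place: 2-hydroxyethyl in place of hydroxy on a double-bonded nitrogen. For the measured compounds named here, no measured step touches the double-bonded nitrogen, so nothing here speaks for a large move in either direction. Compound 4 is therefore expected to stay close to compound 1, with a step of about a 1.2-fold higher number from compound 1 to compound 4 (0.06 log units; within the scatter). The estimate for compound 4 is 450000 nM, within a range from 180000 nM to 1100000 nM.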

Compound 4, half-maximal inhibitory concentration: 1480000 nM
For compound 4 the middle estimate is 3.3-fold (0.52 log units) below the measured one, and the stated range ends below it.
By their numbers in this assay, from the lowest: compounds 3, 1 and 2 (each within the scatter of the next); then compound 4.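

In this assay putting 2-hydroxyethyl in place of hydroxy on the double-bonded nitrogen gives a 3.8-fold higher number from compound 1 to compound 4 (0.58 log units; beyond the scatter) and so a weaker inhibitor, the first step among these compounds to lie beyond the scatter. The only earlier step, the loss of the ring methyl, could not be told apart from noise, so the double-bonded nitrogen is the one place shown so far where a single change clearly moves the number. The entering group adds heavy atoms but has the same count of hydrogen-bond donors and acceptors as hydroxy, and no measurement shown accounts for the step.

The compounds shown leave open whether the loss comes from the oxygen no longer sitting directly on the nitrogen or from the added carbons, which a methoxy group, a plain ethyl group or a longer chain ending in hydroxy could help separate. They also leave open how an amine or a carboxylic acid at the end of the chain would read, and whether the same change would have a similar effect on the core of compound 2, which lacks the methyl.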